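This account rests on a few compounds, and the source may have more. Where it says the series, first, only, none or still open, it means among the compounds named here.

Measured in a physicochemical assay for solubility, in phosphate buffer, at pH 7.4; on this read-out higher numbers stand for higher solubility and lower numbers for lower solubility:
compound 1 `CC(C)n1nc(-c2ccnc3[nH]c(C4CCN(CC(=O)N(C)C)CC4)cc23)ccc1=O` gives 11000 nM
compound 2 `Cc1nc2ccc(-c3ccnc4[nH]c(C5CCN(CC(=O)N(C)C)CC5)cc34)cc2n1C(C)C` gives 26000 nM

Compound 1 holds the lower of the two numbers; the gap to compound 2 is beyond the scatter. Going by the values given here, with only two measured points and no single-change step between them, no trend can be drawn from the numbers so far.

Compound 3 `CN(C)C(=O)CN1CCC(c2cc3c(-c4ccc(=O)n(C)c4)ccnc3[nH]2)CC1` is not yet measured in this assay. Relative to compound 1 it carries the change (a group of 8 heavy atoms (6 carbon, 1 nitrogen, 1 oxygen; one six-membered aromatic ring with 1 hetero atom) in place of a group of 10 heavy atoms (7 carbon, 2 nitrogen, 1 oxygen; one six-membered aromatic ring with 2 hetero atoms), on an aromatic carbon). Among the compounds with values here, no measured pair shows this change, so the expectation rests on compound 1 and the change alone. In this assay the step is expected to be small, most likely none beyond the scatter, with a slight rise as the more probable direction if any. The estimate for compound 3 is 15000 nM. For compound 3 the expected range runs from 6000 nM to 40000 nM. This estimate corresponds to an expected step of a 1.4-fold higher number from compound 1 to compound 3 (0.13 log units; within the scatter).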

Compound 3, solubility: > 1000000 nM
Compound 3: a limit, no number; the forecaster's own chance of this, stated with the estimate: 5%; middle value at least 66-fold (1.82 log units) away from the limit.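

Replacing the group of 10 heavy atoms with the group of 8 heavy atoms, on an aromatic carbon opposite the ring nitrogen, gives in this assay an at least 90-fold higher number from compound 1 to compound 3 (1.95 log units; beyond the scatter), a large step at a place where no single change had been read before. The value for compound 3 is a limit of the assay and not a number, so the full size of this step stays unknown: the limit of > 1000000 nM in this assay, at which 1 of the 3 values shown sits.

Compound 1 and compound 2 differ in more than one place, which leaves this as the only single-change step in the series shown.

The step cannot be divided between the loss of one ring hetero atom and the loss of heavy atoms, as the change alters both together. Also open, from the compounds shown here alone, is how a phenyl group or a morpholine on the same aromatic carbon would read in this assay.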